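Swapping the Indole for a Dimethylphenol

The source may hold more compounds than are shown below. What is called first, only, known or untested is meant among the compounds shown, and "the series" means these compounds.

Compound 1 `CN(C)CCn1cnnc1-c1cc(Oc2ccc(NC(=O)N/N=C/c3c[nH]c4ccccc34)cc2F)ccn1` is the strongest inhibitor of the three measured compounds in a functional assay on MKN-45 cells (Homo sapiens) for cytotoxicity, read by MTT assay, with a stated time of 72 h (a lower number here means a stronger inhibitor, a higher number a weaker inhibitor), where compound 1 gives 790 nM. Compound 2 `CN(C)CCn1cnnc1-c1cc(Oc2ccc(NC(=O)N/N=C/c3ccc(O)c(O)c3)cc2F)ccn1` gives 3240 nM, and compound 3 `COc1ccc(/C=N/NC(=O)Nc2ccc(Oc3ccnc(-c4nncn4CCN(C)C)c3)c(F)c2)cc1O` gives 2510 nM; between these two, a 1.3-fold lower number from compound 2 to compound 3 (0.11 log units; within the scatter). Compound 4 `Cc1cc(/C=N/NC(=O)Nc2ccc(Oc3ccnc(-c4nncn4CCN(C)C)c3)c(F)c2)cc(C)c1O` differs from compound 1 by a single change: 4-hydroxy-3,5-dimethylphenyl in place of 1H-indol-3-yl on a carbon with a double bond to nitrogen. Within the data shown here, two measured steps bear on it, each replacing the same indole with a phenyl ring carrying a hydroxyl: a 4.1-fold higher number from compound 1 to compound 2 (0.61 log units; beyond the scatter) and a 3.2-fold higher number from compound 1 to compound 3 (0.50 log units; beyond the scatter). Both are modest weakenings, so a weakening of about that size is expected for compound 4 as well. The estimate for compound 4 is 2500 nM, with a range from 1000 nM to 6300 nM, meaning an expected step of a 3.2-fold higher number from compound 1 to compound 4 (0.50 log units; beyond the scatter).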

Compound 4, half-maximal inhibitory concentration: 1510 nM
For compound 4 the middle estimate is 1.7-fold (0.22 log units) above the measured one; the measured number falls inside the stated range.
By their numbers in this assay, from the lowest: compounds 1, 4, 3 and 2 (each within the scatter of the next, the first and the last beyond it).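

Swapping the indole for a phenyl ring need not give a step beyond the scatter, as it did for compound 2 and compound 3: a 1.9-fold higher number from compound 1 to compound 4 (0.28 log units; within the scatter) stays within it. Among the phenyl rings, a 2.1-fold lower number from compound 2 to compound 4 (0.33 log units; beyond the scatter) lies beyond the scatter, while a 1.7-fold lower number from compound 3 to compound 4 (0.22 log units; within the scatter) stays within it, so 4-hydroxy-3,5-dimethylphenyl stands apart only from 3,4-dihydroxyphenyl. Nothing available explains these differences.

Open, from the compounds shown here alone, is whether the two methyl groups or the hydroxyl carry the effect, and how a phenyl ring bearing an amine or a carboxylic acid instead would behave.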